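Amine nitrogen substituents: from compound 2 to compound 4

This account rests on a few compounds, and the source may have more. Where it says the series, first, only, none or still open, it means among the compounds named here.

In a functional assay on HeLa cells (Homo sapiens) for inhibition, read by MTT assay, with a stated time of 48 h (on this read-out higher numbers stand for weaker inhibition and lower numbers for stronger inhibition), compound 2 `CCOC(=O)C1=C(N/N=C(/C#N)C(=O)OCC)Nc2[nH]nc(C)c2C1c1ccc(N(C)C)cc1` gives 39200 nM. Compound 3 `CCOC(=O)C1=C(N/C=N/c2nnc(S(N)(=O)=O)s2)Nc2[nH]nc(C)c2C1c1ccc(N(C)C)cc1` gives 26300 nM, a gap within the scatter, with a 1.5-fold lower number from compound 2 to compound 3 (0.17 log units; within the scatter). Compound 1 `CCOC(=O)C1=C(NN=C(C(C)=O)C(C)=O)Nc2[nH]nc(C)c2C1c1ccc(N(C)C)cc1` gives 17000 nM, and only this gap lies beyond the scatter, with a 2.3-fold higher number from compound 1 to compound 2 (0.36 log units; beyond the scatter). Compound 4 `CCOC(=O)C1=C(N/N=C(/Cl)c2ccc([N+](=O)[O-])cc2)Nc2[nH]nc(C)c2C1c1ccc(N(C)C)cc1` carries a group of 12 heavy atoms (7 carbon, 2 nitrogen, 2 oxygen, 1 chlorine; one six-membered aromatic ring of carbon only) in place of a group of 9 heavy atoms (5 carbon, 2 nitrogen, 2 oxygen; no ring), on an amine nitrogen. Among these three measured compounds, changes on this nitrogen stay small: bringing in a ring gave only a 1.5-fold higher number from compound 1 to compound 3 (0.19 log units; within the scatter). Within the data shown here, no measured compound has a six-membered aromatic ring of carbon only in this group, so the data leave the direction weakly defined. A slightly lower number is expected in this assay, with no shift beyond the scatter: a 1.6-fold lower number from compound 2 to compound 4 (0.20 log units; within the scatter). Compound 4 is estimated at 25000 nM, with a range of 9000 nM to 70000 nM.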

Compound 4, half-maximal inhibitory concentration: 46200 nM
Beside the measured number, compound 4's estimate is 1.8-fold (0.27 log units) below it; the range from low to high includes it.
By their numbers in this assay, from the lowest: compounds 1, 3, 2 and 4 (each within the scatter of the next, the first and the last beyond it).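

On this amine nitrogen, a group with a six-membered aromatic ring of carbon only sits with the earlier groups in this assay, with a 1.2-fold higher number from compound 2 to compound 4 (0.07 log units; within the scatter) and a 1.8-fold higher number from compound 3 to compound 4 (0.24 log units; within the scatter). Only a 2.7-fold higher number from compound 1 to compound 4 (0.43 log units; beyond the scatter) lies beyond the scatter, so the group of compound 1 is the only one separated from this new group. No evidence on the cause accompanies these numbers.

On these data alone, whether an amine or a carboxylic acid in this group would give a step beyond the scatter stays open. So do the separate contributions of the chlorine and the nitro group in compound 4.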